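A methyl group added to compound 1

The compounds below may be only part of what the source reports. "The series", "measured", "known", "first", "only" and "open" are said of these compounds alone.

Going by the values given here, in a functional assay on the whole organism with Rattus norvegicus as the target (on this read-out higher numbers stand for an effect only at larger amounts of compound and lower numbers for an effect already at smaller amounts), compound 1 (`O=C(O)c1cc(-c2ccccc2)ccc1O`) gives 54 mg/kg and stands level with its only measured neighbour. In this assay compound 2 (`O=C(O)c1cc(-c2ccc(C(F)(F)F)cc2)ccc1O`) gives 50 mg/kg and the gap is a 1.1-fold lower number from compound 1 to compound 2 (0.03 log units; within the scatter) with neither compound standing apart. Compound 3 (`Cc1cc(-c2ccccc2)cc(C(=O)O)c1O`) differs from compound 1 by methyl in place of hydrogen on an aromatic carbon as methyl in place of hydrogen on an aromatic carbon, ortho to a hydroxy group. Among the compounds with values here, the one measured step, a 1.1-fold lower number from compound 1 to compound 2 (0.03 log units; within the scatter) for a different group, offers only weak guidance, so no step beyond the scatter is expected in this assay here. The expected change is a 1.1-fold lower number from compound 1 to compound 3 (0.03 log units; within the scatter) as an estimate only. For compound 3 the estimate is 50 mg/kg with 22 mg/kg to 110 mg/kg as its expected range.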

Compound 3, dose for half-maximal effect: 60 mg/kg
Compound 3: middle estimate off by 1.2-fold (0.08 log units), on the low side; measured number inside the range.
By their numbers in this assay, from the lowest: compounds 2, 1 and 3 (each within the scatter of the next).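

In this assay, methyl in place of hydrogen on an aromatic carbon, ortho to a hydroxy group, gives a 1.1-fold higher number from compound 1 to compound 3 (0.05 log units; within the scatter) and so leaves the number within the scatter. This position therefore takes one added carbon without a step that can be told from repeat measurements, a point the trifluoromethyl change in compound 2 could not show for this place. No measurement at hand bears on this result.

As far as these compounds go, whether an amine, a methoxy group or a longer chain at this position would give a step beyond the scatter remains open. So does whether methyl would behave alike when combined with the trifluoromethyl of compound 2.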